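The source may hold more compounds than are shown below. What is called first, only, known or untested is meant among the compounds shown, and "the series" means these compounds.

Compound 3 `CC(C)=CCOc1cc(Nc2ncccn2)ccc1Cl` gives 2500 nM in an ADME assay on MT2 cells (Homo sapiens) for cytotoxicity (a lower number here means that less compound is tolerated, a higher number that more compound is tolerated), the lowest of the three numbers measured. Compound 2 `CCOc1ccnc(Nc2ccc(Cl)c(OCC=C(C)C)c2)n1` gives 19000 nM in this assay, and compound 1 `CC(C)=CCOc1cc(Nc2ncnc(N)n2)ccc1Cl` gives 48000 nM. Both steps that lead to compound 3 are beyond the scatter: a 19-fold lower number from compound 1 to compound 3 (1.28 log units; beyond the scatter) and a 7.6-fold lower number from compound 2 to compound 3 (0.88 log units; beyond the scatter). For the measured compounds named here, the first replaces a group on a nitrogen on an aromatic ring, the second removes an ethoxy group from an aromatic carbon.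

Compound 4 `Clc1ccc(Nc2ncccn2)cc1Oc1ccccc1` differs from compound 3 in one place: phenyl in place of 3-methylbut-2-en-1-yl on an oxygen on an aromatic ring. Going by the values given here, neither measured step touches this oxygen, so no measured step bears directly on the change, and the two measured steps give no pull in either direction for it. Because the two steps that are known, a 19-fold lower number from compound 1 to compound 3 (1.28 log units; beyond the scatter) and a 7.6-fold lower number from compound 2 to compound 3 (0.88 log units; beyond the scatter), concern other positions, compound 4 is expected to show a step of a 1.2-fold higher number from compound 3 to compound 4 (0.08 log units; within the scatter) that does not go beyond the scatter. The estimate for compound 4 in this assay is 3000 nM, with a range from 900 nM to 12000 nM.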

Compound 4, half-maximal cytotoxic concentration: 30000 nM
The estimate for compound 4 lay 10-fold (1.00 log units) below the measured number, and the stated range ends below it.
By their numbers in this assay, from the lowest: compound 3; then compounds 2, 4 and 1 (each within the scatter of the next, the first and the last beyond it).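

The oxygen on the aromatic ring turns out to be a sensitive place: phenyl in place of 3-methylbut-2-en-1-yl gives a 12-fold higher number from compound 3 to compound 4 (1.08 log units; beyond the scatter) in this assay and so adds a third change that lies beyond the scatter. Compound 3 now stands lowest against all three neighbours, so each single change shown away from it, including this one at a position the earlier compounds left untouched, goes towards more compound tolerated. Nothing measured here accounts for the size or direction of this step.

The compounds shown do not separate the effect of the aromatic ring from that of losing the double bond, which a benzyl or a saturated 3-methylbutyl group on the same oxygen would address. As far as these compounds go, whether phenoxy behaves alike alongside ethoxy or 4-amino-1,3,5-triazin-2-yl also stays open.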